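Swapping the sulfur-bearing bicycle for a nitrogen-rich one

The source may hold more compounds than are shown below. What is called first, only, known or untested is meant among the compounds shown, and "the series" means these compounds.

Among the three measured compounds, compound 3 `O=C(NCc1ccc(S(=O)(=O)N2CCCCC2)cc1)c1cc2cccnc2s1` gives the lowest number in an assay for inhibition of Nicotinamide phosphoribosyltransferase (Homo sapiens), read by mass spectrometry, with stated times of 15 min and 30 min (on this read-out higher numbers stand for weaker inhibition and lower numbers for stronger inhibition), at 8 nM. Compound 1 `O=C(NCc1ccc(S(=O)(=O)N2CCCCC2)cc1)c1cc2ccncc2[nH]1` gives 1000 nM and compound 2 `O=C(NCc1ccc(S(=O)(=O)N2CCCCC2)cc1)c1ccc2nc[nH]c2c1` gives 310 nM; the gaps to compound 3 were a 130-fold lower number from compound 1 to compound 3 (2.10 log units; beyond the scatter) and a 39-fold lower number from compound 2 to compound 3 (1.59 log units; beyond the scatter), both well beyond the scatter. Compound 4 `O=C(NCc1ccc(S(=O)(=O)N2CCCCC2)cc1)c1ccn2cncc2c1` keeps the shared core but carries a group of 9 heavy atoms (7 carbon, 2 nitrogen; one five-membered aromatic ring with 2 hetero atoms, one six-membered aromatic ring with 1 hetero atom) in place of a group of 9 heavy atoms (7 carbon, 1 nitrogen, 1 sulfur; one five-membered aromatic ring with 1 hetero atom, one six-membered aromatic ring with 1 hetero atom), on a carbonyl carbon. The two steps that bear on this are those leading into compound 3: each time a bicycle containing two nitrogens and no sulfur was replaced by the sulfur-bearing bicycle, the number fell sharply. Of the two, a 39-fold lower number from compound 2 to compound 3 (1.59 log units; beyond the scatter) is the closer analogy; there the five-membered ring of the replaced bicycle also held two hetero atoms. Moving from compound 3 to compound 4 runs the other way, so a large rise in the number in this assay is expected, on the order of a 38-fold higher number from compound 3 to compound 4 (1.57 log units; beyond the scatter). Compound 4 is therefore estimated at 300 nM, with a likely range from 60 nM to 1500 nM.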

Compound 4, half-maximal inhibitory concentration: 1700 nM
Compound 4: middle estimate off by 5.7-fold (0.75 log units), on the low side; measured number above the stated range.
By their numbers in this assay, from the lowest: compound 3; then compound 2; then compounds 1 and 4 (each within the scatter of the next).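

In this assay, the sulfur-bearing bicycle now stands well apart from all three bicycles that hold two nitrogens, as shown by the step of a 210-fold higher number from compound 3 to compound 4 (2.33 log units; beyond the scatter). This large step comes even though the entering and leaving groups match in their counts of hydrogen-bond donors and acceptors, and neither carries a net charge, so those counts alone do not track the result at this place on the carbonyl carbon. The nitrogen-containing bicycles lie much closer together: the step of a 5.5-fold higher number from compound 2 to compound 4 (0.74 log units; beyond the scatter) is modest, and the step of a 1.7-fold higher number from compound 1 to compound 4 (0.23 log units; within the scatter) does not separate the pair.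

From the compounds shown here alone, whether the sulfur itself matters stays open, and a bicycle with oxygen in its place, or with sulfur and a six-membered ring of carbon only, would help test this. Nothing available here explains these differences.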